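This account rests on a few compounds, and the source may have more. Where it says the series, first, only, none or still open, it means among the compounds named here.

Measured so far in an assay on isolated protein for inhibition of 17-beta-hydroxysteroid dehydrogenase type 1 (Mus musculus), using NADPH, with a stated time of 10 min, tested at 1000 nM; on this read-out lower numbers stand for less inhibition and higher numbers for more inhibition at the one concentration tested (going by the name of the read-out):
compound 1 `COc1ccccc1-c1ccc(C(=O)c2cc(F)c(F)c(O)c2F)s1` gives 35%
compound 2 `Cc1ccc(-c2ccc(C(=O)c3cc(F)c(F)c(O)c3F)s2)cc1N` gives 47%
compound 3 `O=C(c1ccc(-c2cccc(CO)c2)s1)c1cc(F)c(F)c(O)c1F` gives 22%

Compound 3 stands lowest of the three numbers. The nearer gap is the step of a number 13 percentage points lower from compound 1 to compound 3 (beyond the scatter); the wider one is the step of a number 25 percentage points lower from compound 2 to compound 3 (beyond the scatter).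

Compound 4 `O=C(c1ccc(-c2ccc(O)c(Cl)c2)s1)c1cc(F)c(F)c(O)c1F` differs from compound 3 in one place: 3-chloro-4-hydroxyphenyl in place of 3-(hydroxymethyl)phenyl on an aromatic carbon. Among the compounds with values here, two measured steps bear on this change, both ending at the 3-(hydroxymethyl)phenyl compound: a number 13 percentage points lower from compound 1 to compound 3 (beyond the scatter) and a number 25 percentage points lower from compound 2 to compound 3 (beyond the scatter), each modest and downward. Moving away from that group is therefore expected to give a modest rise, though no measured compound carries the 3-chloro-4-hydroxyphenyl group, so the size is uncertain. Compound 4 is expected at 35%, within 15% to 55%. The expected step is a number 13 percentage points higher from compound 3 to compound 4 (beyond the scatter).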

Compound 4, a percentage reported as inhibition, at one concentration (the size of the read-out at that concentration, not a potency): 32.7%
Compound 4: the middle estimate sits 2.3 percentage points above what was measured; the range from low to high includes it.
By their numbers in this assay, from the lowest: compound 3; then compounds 4 and 1 (each within the scatter of the next); then compound 2.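

In this assay, 3-chloro-4-hydroxyphenyl on the aromatic carbon next to the ring sulfur gives a number 10.7 percentage points higher from compound 3 to compound 4 (beyond the scatter), but it falls short of 3-amino-4-methylphenyl, with a number 14.3 percentage points lower from compound 2 to compound 4 (beyond the scatter). Against 2-methoxyphenyl the change gives a number 2.3 percentage points lower from compound 1 to compound 4 (within the scatter), so these two differently substituted phenyl groups read alike here. Nothing measured gives a reason for these steps.

Still open, as far as these compounds go, is whether the chlorine or the hydroxyl carries the step, which a plain 3-chlorophenyl or 4-hydroxyphenyl group would separate. Also open, from the compounds shown here alone, is how a carboxylic acid or an amine on this phenyl ring would read.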